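Compound 3 to compound 4: a propargylcarbamoyl change

This account rests on a few compounds, and the source may have more. Where it says the series, first, only, none or still open, it means among the compounds named here.

Values in a functional assay on Caco-2 cells (Homo sapiens), read by MTT assay, with a stated time of 48 h (on this read-out higher numbers stand for weaker inhibition and lower numbers for stronger inhibition), are as follows.
- compound 1 (`CCn1c(C(=O)NCCCN(C)C)ccc1C(CC)(CC)c1ccc(OCC(O)C(C)(C)C)c(C)c1`) at 1900 nM
- compound 2 (`CCN(CC)CCCNC(=O)c1ccc(C(CC)(CC)c2ccc(OCC(O)C(C)(C)C)c(C)c2)n1CC`) at 1800 nM
- compound 3 (`C#CCNC(=O)c1ccc(C(CC)(CC)c2ccc(OCC(O)C(C)(C)C)c(C)c2)n1CC`) at 39100 nM

Compound 3 has the highest number of the three and is the weakest inhibitor here. Compound 4 (`CCn1c(C(=O)NCC(OC)OC)ccc1C(CC)(CC)c1ccc(OCC(O)C(C)(C)C)c(C)c1`) carries dimethoxymethyl in place of ethynyl on a saturated chain carbon bound to an amide-type nitrogen. Two large steps bear on this: a 21-fold higher number from compound 1 to compound 3 (1.31 log units; beyond the scatter) and a 22-fold higher number from compound 2 to compound 3 (1.34 log units; beyond the scatter) each put ethynyl where a 2-(dialkylamino)ethyl group stood. The exchange of dimethylamino for diethylamino, a 1.1-fold lower number from compound 1 to compound 2 (0.02 log units; within the scatter), stays within the scatter. Compound 4, like compound 3, has neither amino group, so it is expected to sit apart from compound 1 and compound 2 and near compound 3 at 39100 nM in this assay with no step beyond the scatter. Within the data shown here, no measured compound carries dimethoxymethyl, so this expectation is loose. The expected change is a 1.3-fold lower number from compound 3 to compound 4 (0.12 log units; within the scatter) and no more. For compound 4 the estimate is 30000 nM as a central value. The estimated range for compound 4 runs from 12000 nM to 60000 nM in this read-out.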

Compound 4, half-maximal inhibitory concentration: > 50000 nM
Compound 4: no number, only a limit; the forecaster's own chance of this, stated with the estimate: 15%; middle value at least 1.6-fold (0.22 log units) from the limit.
By their numbers in this assay, from the lowest: compounds 2 and 1 (each within the scatter of the next); then compound 3. At a limit, above all of these: compound 4.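

In this assay compound 4 reads only as a limit of the assay, not as a number: the limit of > 50000 nM in this assay, at which 1 of the 4 values shown sits.

Replacing either 2-(dialkylamino)ethyl group with dimethoxymethyl gives large steps, an at least 27-fold higher number from compound 2 to compound 4 (1.44 log units; beyond the scatter) and an at least 26-fold higher number from compound 1 to compound 4 (1.42 log units; beyond the scatter), so the large rise seen with ethynyl at this place recurs with a second group lacking the amino function. The remaining step, an at least 1.2-fold higher number from compound 3 to compound 4 (0.10 log units; that floor lies within the scatter), has a floor within the scatter, so compound 3 and compound 4 cannot be ordered, and the 2 hydrogen-bond acceptors of dimethoxymethyl bring no lower number.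

Still open, on these data alone, is whether a tertiary amine is needed at this place, or whether a primary amine, a morpholine or a hydroxyl would serve as well. Also open, as far as these compounds go, is how a shorter or longer chain between the amide nitrogen and the dimethylamino group would read, and whether a carboxylic acid would behave like the neutral groups.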